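Inverting five stereocentres in a hydroxyglutarate ester

The compounds below may be only part of what the source reports. "The series", "measured", "known", "first", "only" and "open" are said of these compounds alone.

Measured compounds:
compound 1, `CC[C@H](C)C(=O)O[C@@H]1CCC=C2C=C[C@@H](C)[C@@H](COC(=O)CCCC(=O)O)[C@@H]21`, 110000 nM
compound 2, `CC[C@H](C)C(=O)O[C@H]1CCC=C2C=C[C@H](C)[C@H](COC(=O)C[C@H](O)CC(=O)O)[C@H]21`, 5000 nM

Both compounds were examined in an assay on microsomes from liver for inhibition of 3-hydroxy-3-methylglutaryl-coenzyme A reductase (Rattus norvegicus); on this read-out lower numbers stand for stronger inhibition and higher numbers for weaker inhibition. Compound 1 gives 110000 nM, while compound 2 gives 5000 nM; of the two numbers, that of compound 2 is the lower, and the gap between the two lies beyond the scatter of repeated measurements.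

Compound 3, `CC[C@H](C)C(=O)O[C@@H]1CCC=C2C=C[C@@H](C)[C@@H](COC(=O)C[C@@H](O)CC(=O)O)[C@@H]21`, has not yet been measured in this assay. Its relation to compound 2 is one of configuration only: the two compounds have the same atoms and bonds and differ only in configuration as drawn: 5 of 6 stereo elements differ; a stereocentre at a saturated ring carbon is drawn S in compound 2 and R in compound 3; a stereocentre at a saturated ring carbon is drawn S in compound 2 and R in compound 3; a stereocentre at a saturated ring carbon is drawn S in compound 2 and R in compound 3; a stereocentre at a saturated chain carbon is drawn R in compound 2 and S in compound 3. Nothing changes in the atoms or bonds; the sec-butyl ester stereocentre is the single element held in common.

For the measured compounds named here, no measured pair in this set differs in configuration alone, so the size of this step is not known from the data. Since the two compounds share every atom, the account rests on the expectation that inverting five stereo elements at once will not leave inhibition untouched. Compound 3 is expected to show a step of a 12-fold higher number from compound 2 to compound 3 (1.08 log units; beyond the scatter), towards a higher number and beyond the scatter. For compound 3 the estimate is therefore 60000 nM, within a range from 10000 nM to 300000 nM.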

Compound 3, half-maximal inhibitory concentration: > 25000 nM
Compound 3 ended at the assay's limit (the forecaster's own chance of this, stated with the estimate: 15%); the middle value lies beyond the limit too.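

In this assay the new result shows a step of an at least 5.0-fold higher number from compound 2 to compound 3 (0.69 log units; beyond the scatter), and this step can be assigned to configuration alone, which the earlier pair of compound 1 and compound 2 could not show: the fact that compounds 2 and 3 differ only in the configuration as drawn

For compound 3 the value > 25000 nM is a limit of the assay and not a number. The step from compound 2 is therefore a minimum, and the step from compound 1 to compound 3, with hydroxy in place of hydrogen on a saturated chain carbon bound to two saturated chain carbons, cannot be read: the limit of > 25000 nM in this assay, at which 1 of the 3 values shown sits.

From the compounds shown here alone, all the inverted stereo elements change together, so it remains open whether the stereocentres at the saturated ring carbons, the stereocentre at the saturated chain carbon, or some combination of them accounts for the step. Going by these compounds, it also remains open how inhibition in this assay would respond if an amine stood in place of the hydroxy on the saturated chain carbon, in either configuration.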